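The source may hold more compounds than are shown below. What is called first, only, known or untested is meant among the compounds shown, and "the series" means these compounds.

Three compounds have been measured in a functional assay on Lu cells (Homo sapiens) for antiproliferative activity; a lower number here means a stronger inhibitor, a higher number a weaker inhibitor:

Compound 1 `COc1ccc(/C=C/C(=O)c2ccc(OCCn3cc(CN4C(=O)/C=C/C(C)(C)C/C=C(\C)CC/C=C/4C)nn3)cc2O)cc1` gives 1.67 ug/mL.
Compound 2 `COc1cccc(/C=C/C(=O)c2ccc(OCCn3cc(CN4C(=O)/C=C/C(C)(C)C/C=C(\C)CC/C=C/4C)nn3)cc2O)c1` gives 0.61 ug/mL.
Compound 3 `COc1ccc(/C=C/C(=O)c2ccc(OCCCN3C(=O)/C=C/C(C)(C)C/C=C(\C)CC/C=C/3C)cc2)cc1` gives 2.56 ug/mL.

Compound 1 and compound 2 differ in one place: 3-methoxyphenyl in place of 4-methoxyphenyl on a double-bonded chain carbon bound to a double-bonded chain carbon. This single change made a 2.7-fold lower number from compound 1 to compound 2 (0.44 log units; beyond the scatter), a shift beyond the usual scatter of this assay. Compound 3 carries a different core from compound 1 and compound 2; the two cores differ in more than one place, and that difference is not broken down here. Compound 3 sits at the highest number of the three, within the scatter of compound 1 and beyond it from compound 2.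

Compound 4 `COc1cccc(/C=C/C(=O)c2ccc(OCCCN3C(=O)/C=C/C(C)(C)C/C=C(\C)CC/C=C/3C)cc2)c1` is not yet measured. It stands to compound 3 exactly as compound 2 stands to compound 1: 3-methoxyphenyl in place of 4-methoxyphenyl on a double-bonded chain carbon bound to a double-bonded chain carbon. Because the earlier case of this change gave a 2.7-fold lower number from compound 1 to compound 2 (0.44 log units; beyond the scatter), the same change is expected to bring a 2.3-fold lower number from compound 3 to compound 4 (0.37 log units; beyond the scatter) on the core of compound 3, with some added uncertainty since only one earlier case exists. Compound 4 is therefore estimated at 1.1 ug/mL, most likely between 0.5 ug/mL and 2.5 ug/mL.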

Compound 4, half-maximal inhibitory concentration: 1.06 ug/mL
The estimate for compound 4 lay 1.0-fold (0.02 log units) above the measured number; the measured number falls inside the stated range.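

In this assay, putting 3-methoxyphenyl in place of 4-methoxyphenyl gave a 2.4-fold lower number from compound 3 to compound 4 (0.38 log units; beyond the scatter), so the change lowered the number on the core of compound 3 as well. Set beside the earlier case, the two steps match in size: the same change on two cores in this assay, a 2.7-fold lower number (0.44 log units; beyond the scatter) from compound 1 to compound 2 and a 2.4-fold lower number (0.38 log units; beyond the scatter) from compound 3 to compound 4, 1.1-fold (0.05 log units) apart, within the scatter of two such steps. This shows that the change carried over between these two cores with much the same size, but two pairs are too few to promise the same result on any further core in the series, and the numbers alone do not say why the 3-methoxyphenyl compounds give the lower values.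

Going by these compounds, it remains open whether the methoxy group itself matters, or whether another group in the same place, such as a plain phenyl or a 3-chlorophenyl, would lower the number just as far on either core. On these data alone, it is also open whether the step would keep its size on a core with a longer chain leading to the large ring.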